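Swapping 4-methylphenyl for 3-(1-hydroxyethyl)phenyl

The source may hold more compounds than are shown below. What is called first, only, known or untested is meant among the compounds shown, and "the series" means these compounds.

In a physicochemical assay for solubility (on this read-out lower numbers stand for lower solubility and higher numbers for higher solubility), compound 1 `CNC(=O)c1cc(C(=O)NC2CC2)cn(Cc2ccc(C)cc2)c1=O` gives 24 ug/mL. Compound 2 `CNC(=O)c1cc(C(=O)NCC(C)C)cn(Cc2ccccc2)c1=O` gives 43 ug/mL, and these two numbers lie within the scatter of each other, so compound 1 stands level with compound 2 on the numbers available. Compound 3 `CNC(=O)c1ccc(=O)n(Cc2ccccc2)c1` reads >= 108 ug/mL, which is a limit of the assay and not a number.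

Compound 4 `CNC(=O)c1cc(C(=O)NC2CC2)cn(Cc2cccc([C@@H](C)O)c2)c1=O` differs from compound 1 in one place: 3-(1-hydroxyethyl)phenyl in place of 4-methylphenyl on a saturated chain carbon bound to an aromatic nitrogen. Within the data shown here, no measured pair isolates this change, so the expectation rests on the structural change alone, starting from compound 1 at 24 ug/mL. A modest upward step in this assay is expected, only slightly beyond the scatter, and a result within the scatter would remain plausible. The estimate amounts to an expected 2.5-fold higher number from compound 1 to compound 4 (0.40 log units; beyond the scatter). Compound 4 is estimated at 60 ug/mL, with an expected range from 28 ug/mL to 130 ug/mL.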

Compound 4, solubility: >= 131 ug/mL
Compound 4 gave a limit, no number; the forecaster's own chance of this, stated with the estimate: 20%; middle value at least 2.1-fold (0.33 log units) away from the limit.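

Among these compounds, replacing 4-methylphenyl with 3-(1-hydroxyethyl)phenyl on a saturated chain carbon bound to an aromatic nitrogen gives the first single-place comparison, and in this assay it comes with an at least 5.4-fold higher number from compound 1 to compound 4 (0.73 log units; beyond the scatter). Compound 4 reads >= 131 ug/mL, which is a limit of the assay and not a number. The step therefore shows only a minimum, and its full size cannot be read because the value of compound 4 sits at a limit: the limit of >= 131 ug/mL in this assay, at which 1 of the 4 values shown sits.

This one pair does not separate the loss of the 4-methyl group from the gain of the 1-hydroxyethyl group or its defined stereocentre. Also open, from the compounds shown here alone, is how the other stereoisomer, or a phenyl ring carrying an aminomethyl group or a carboxylic acid in place of 1-hydroxyethyl, would read in this assay.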